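The compounds below may be only part of what the source reports. "The series", "measured", "known", "first", "only" and "open" are said of these compounds alone.

Three compounds sharing one core and differing in a single aryl group have been measured in a functional assay on MDA-MB-436 cells (Homo sapiens) for antiproliferative activity, read by MTT assay, with a stated time of 48 h; a higher number here means a weaker inhibitor, a lower number a stronger inhibitor. Compound 1 `C=CS(=O)(=O)N1CCN(c2ncnc3sc(-c4ccc(OC)cc4)cc23)CC1` carries 4-methoxyphenyl and gives 28400 nM in this test. Compound 2 `C=CS(=O)(=O)N1CCN(c2ncnc3sc(-c4ccc(C#N)cc4)cc23)CC1` carries 4-cyanophenyl and gives 9170 nM under the same conditions. Compound 3 `C=CS(=O)(=O)N1CCN(c2ncnc3sc(-c4cccc5ccccc45)cc23)CC1` carries naphthalen-1-yl and gives 28100 nM as its reading. Compound 3 thus sits with compound 1 at the high-number end of the set, the step between them (a 1.0-fold lower number from compound 1 to compound 3 (0.00 log units; within the scatter)) lying within the scatter, while compound 2 stands apart (a 3.1-fold higher number from compound 2 to compound 3 (0.49 log units; beyond the scatter)).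

Compound 4 `C=CS(=O)(=O)N1CCN(c2ncnc3sc(-c4cccc5ncccc45)cc23)CC1` exchanges the naphthalen-1-yl of compound 3 for quinolin-5-yl quinolin-5-yl in place of naphthalen-1-yl on an aromatic carbon on the aromatic carbon next to the ring sulfur. Among the measured compounds shown here, no measured step makes this exact exchange. The closest guides are the other changes at the same place, of which the largest (a 3.1-fold lower number from compound 1 to compound 2 (0.49 log units; beyond the scatter)) is modest and the other (a 1.0-fold lower number from compound 1 to compound 3 (0.00 log units; within the scatter)) is nil. A small move towards a lower number in this assay is therefore expected, one that may not clear the scatter. The estimated change is a 1.7-fold lower number from compound 3 to compound 4 (0.22 log units; within the scatter) and no more than that is expected. For compound 4 the estimated value is 17000 nM with an expected range from 7000 nM to 40000 nM in this test.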

Compound 4, half-maximal inhibitory concentration: 25900 nM
Compound 4: middle estimate off by 1.5-fold (0.18 log units), on the low side; measured number inside the range.
By their numbers in this assay, from the lowest: compound 2; then compounds 4, 3 and 1 (each within the scatter of the next).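

In this assay, quinolin-5-yl and naphthalen-1-yl cannot be told apart on the aromatic carbon next to the ring sulfur (a 1.1-fold lower number from compound 3 to compound 4 (0.04 log units; within the scatter)), even though quinolin-5-yl brings a ring nitrogen and a hydrogen-bond acceptor that naphthalen-1-yl lacks. Quinolin-5-yl also cannot be separated from the 4-methoxyphenyl of compound 1 (a 1.1-fold lower number from compound 1 to compound 4 (0.04 log units; within the scatter)), so three different aryl groups at this position now give readings within the scatter of one another. Only the 4-cyanophenyl of compound 2 stands apart from this group, and the new comparison confirms that with a step that is modest but beyond the scatter (a 2.8-fold higher number from compound 2 to compound 4 (0.45 log units; beyond the scatter)), leaving compound 2 with the lowest number of the four.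

The data shown offer no explanation for why the hydrogen-bond acceptor of quinolin-5-yl leaves the reading where it is, or for why 4-cyanophenyl stands apart. Also open, on these data alone, is whether a carboxylic acid or an aminomethyl group in place of the nitrile on the phenyl ring would keep, extend or lose the step seen with compound 2.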